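This account rests on a few compounds, and the source may have more. Where it says the series, first, only, none or still open, it means among the compounds named here.

Measured in a functional assay on HeLa S3 cells (Homo sapiens) for antiproliferative activity, read by XTT assay, with a stated time of 72 h; on this read-out lower numbers stand for stronger inhibition and higher numbers for weaker inhibition:
- compound 1 `C#Cc1cn([C@@H]2O[C@H](CO)[C@@H](O)[C@H]2O)c2ncnc(SC)c12`: 110 nM
- compound 2 `CNc1ncnc2c1c(-c1cccs1)cn2[C@@H]1O[C@H](CO)[C@@H](O)[C@H]1O`: > 20000 nM (a limit)
- compound 3 `CNc1ncnc2c1c(-c1ccsc1)cn2[C@@H]1O[C@H](CO)[C@@H](O)[C@H]1O`: > 20000 nM (a limit)

Compound 3 reads > 20000 nM, which is a limit and not a number. Compound 2 stands with it: the limit of > 20000 nM in this assay, at which 2 of the 3 values shown sit. Among the compounds with values here, the one measured step is a step that the two limits leave unreadable from compound 2 to compound 3, so it offers no size to carry forward.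

Compound 4 `C#Cc1cn([C@@H]2O[C@H](CO)[C@@H](O)[C@H]2O)c2ncnc(NC)c12` is not yet measured. The change is ethynyl in place of thiophen-3-yl on an aromatic carbon. Within the data shown here, no measured step covers this exchange. Compound 1 also carries ethynyl and gives 110 nM, so a measurable number is expected for compound 4. The expected move is an at least 20-fold lower number from compound 3 to compound 4 (1.30 log units; beyond the scatter), towards stronger inhibition, with its size only loosely set. Compound 4 is estimated at 1000 nM, with an expected range of 100 nM to 10000 nM.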

Compound 4, half-maximal inhibitory concentration: > 20000 nM
Compound 4 ended at the assay's limit (the forecaster's own chance of this, stated with the estimate: 30%); at least 20-fold (1.30 log units) between middle value and limit.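

In this assay compound 4 reads > 20000 nM, a limit and not a number. Ethynyl is kept while methylamino stands in place of methylsulfanyl, giving an at least 180-fold higher number from compound 1 to compound 4 (2.25 log units; beyond the scatter), so ethynyl alone does not secure the activity of compound 1. The steps from compound 2 and compound 3 to compound 4 cannot be read, and the limit is now shared more widely: the limit of > 20000 nM in this assay, at which 3 of the 4 values shown sit.

Open, going by these compounds, is whether thiophen-2-yl or thiophen-3-yl would give a measurable number alongside methylsulfanyl. Also open, on these data alone, is how an unsubstituted amino group or a methoxy group would behave in place of methylamino with ethynyl kept.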